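Notes on the amide aryl group: compound 2 to compound 3

This account rests on a few compounds, and the source may have more. Where it says the series, first, only, none or still open, it means among the compounds named here.

For the measured compounds named here, in a functional assay on DLD-1 cells (Homo sapiens) (on this read-out lower numbers stand for stronger inhibition and higher numbers for weaker inhibition), compound 1 `N#Cc1ccc(Cn2cncc2CN(C(=O)c2cccc(Cl)c2)c2ccc(N3CCN(C(=O)c4ccc(Cl)s4)CC3)cc2)cc1` gives 2 nM, while compound 2 `N#Cc1ccc(Cn2cncc2CN(C(=O)c2ccccc2F)c2ccc(N3CCN(C(=O)c4ccc(Cl)s4)CC3)cc2)cc1` gives 20 nM, the higher of the two numbers; the only step, a 10-fold higher number from compound 1 to compound 2 (1.00 log units; beyond the scatter), came with 2-fluorophenyl replacing 3-chlorophenyl. Compound 3 `COc1cccc(C(=O)N(Cc2cncn2Cc2ccc(C#N)cc2)c2ccc(N3CCN(C(=O)c4ccc(Cl)s4)CC3)cc2)c1` carries 3-methoxyphenyl in place of 2-fluorophenyl on a carbonyl carbon. Going by the values given here, no measured step covers a methoxy group, but the 3-methoxyphenyl of compound 3 resembles the 3-chlorophenyl of compound 1 more than the 2-fluorophenyl of compound 2, so a step back toward compound 1 is expected, of size a 3.3-fold lower number from compound 2 to compound 3 (0.52 log units; beyond the scatter) in this assay. Compound 3 is therefore estimated at 6 nM, within 2 nM to 20 nM.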

Compound 3, half-maximal inhibitory concentration: 7 nM
For compound 3 the middle estimate is 1.2-fold (0.07 log units) below the measured one; measured number inside the range.
By their numbers in this assay, from the lowest: compound 1; then compound 3; then compound 2.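

On the carbonyl carbon, 3-methoxyphenyl reads better than 2-fluorophenyl (a 2.9-fold lower number from compound 2 to compound 3 (0.46 log units; beyond the scatter)), so the loss seen with 2-fluorophenyl is not a general feature of replacing 3-chlorophenyl. Methoxy in place of chloro on an aromatic carbon still gives a step beyond the scatter (a 3.5-fold higher number from compound 1 to compound 3 (0.54 log units; beyond the scatter)), so the identity of the group matters even where only that group changes. The step from 2-fluorophenyl changes both the group and its name-position, so it cannot separate the two.

A 2-chlorophenyl or 3-aminophenyl group on this carbonyl carbon would help to separate them. No measured evidence bears on why these steps arise.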